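The compounds below may be only part of what the source reports. "The series", "measured", "known", "first", "only" and "open" are said of these compounds alone.

Compound 1 `Cc1ccc2[nH]c(=O)c(CN(Cc3ccc(O)cc3)Cc3ccc(C(C)(C)C)cc3)cc2c1` gives 4900 nM in a toxicity assay on MDCK cells (Canis lupus familiaris) for cytotoxicity, read by crystal violet staining, with a stated time of 48 h; a higher number here means that more compound is tolerated, a lower number that less compound is tolerated. Compound 2 `CCc1ccc2[nH]c(=O)c(CN(Cc3ccc(O)cc3)Cc3ccc(C(C)(C)C)cc3)cc2c1` reaches only the limit of > 10000 nM in this assay. Compound 3 `CC(C)c1ccc2[nH]c(=O)c(CN(Cc3ccc(C(C)(C)C)cc3)C(C)c3ccc(F)cc3)cc2c1` gives 13100 nM in this assay.

Among the two numbers shown, compound 1 has the lowest; compound 3 gives a higher number, and that gap lies beyond the scatter. Compound 4 `Cc1ccc2[nH]c(=O)c(CN(Cc3ccc(C(C)(C)C)cc3)C(C)c3ccc(OC(F)F)cc3)cc2c1`, not yet measured, differs from compound 1 in one place: 1-(4-(difluoromethoxy)phenyl)ethyl in place of 4-hydroxybenzyl on an amine nitrogen. Only one measured step is shown, an at least 2.0-fold higher number from compound 1 to compound 2 (0.30 log units; that floor lies within the scatter), and it is a change at the core, not at the amine nitrogen, so it bears only loosely on the present change; its floor lies within the scatter. For the measured compounds named here, compound 3, which carries a 1-arylethyl group on the same nitrogen together with a different core substituent, has no step computed against compound 1, so only its higher number can be noted. On that slender basis a modest rise is expected, a 1.8-fold higher number from compound 1 to compound 4 (0.26 log units; within the scatter). Compound 4 is therefore estimated to give 9000 nM in this assay, within a range from 4000 nM to 20000 nM, with a fair chance that only a limit is reported, as for compound 2 (the limit of > 10000 nM in this assay, at which 1 of the 3 values shown sits).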

Compound 4, half-maximal cytotoxic concentration: > 5000 nM
Compound 4: a limit, no number; the forecaster's own chance of this, stated with the estimate: 35%; the middle value lies beyond the limit too.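

In this assay, for the compounds shown here, 1-(4-(difluoromethoxy)phenyl)ethyl in place of 4-hydroxybenzyl on an amine nitrogen gives the first step at this position, an at least 1.0-fold higher number from compound 1 to compound 4 (0.00 log units; that floor lies within the scatter). This step has a floor and no size, and the change, which leaves no hydrogen-bond donor in the group on that nitrogen, brings no fall in the number that can be read. The result for compound 4 is a limit and not a number: the limit of > 5000 nM in this assay, at which 1 of the 4 values shown sits.

How far compound 4 lies beyond its limit stays open, and the compounds shown cannot separate the added methyl on the chain carbon from the swap of hydroxyl for difluoromethoxy, since both arrive in one change. Also open, from the compounds shown here alone, is how an amine or a carboxylic acid in place of difluoromethoxy would read in this assay.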